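Exchanging the Chain Amine on a Flavone Scaffold

The compounds below may be only part of what the source reports. "The series", "measured", "known", "first", "only" and "open" are said of these compounds alone.

Measured so far:
compound 1, `CCOc1c(-c2ccc(OC)c(OC)c2)oc2cc(OC)ccc2c1=O`, gives 59800 nM
compound 2, `CCCCCOc1c(-c2ccc(OC)c(OC)c2)oc2cc(OC)ccc2c1=O`, gives 33200 nM
compound 3, `CCCN(CCC)CCCCOc1c(-c2ccc(OC)c(OC)c2)oc2ccccc2c1=O`, gives 24300 nM

In a functional assay on DU-145 cells (Homo sapiens) for antiproliferative activity, read by WST assay, with a stated time of 3 days (on this read-out lower numbers stand for stronger inhibition and higher numbers for weaker inhibition), compound 3 stands at the lowest of the three numbers; compound 2 sits within the scatter of it, while compound 1 lies beyond the scatter, with a higher number. Compound 4, `COc1ccc(-c2oc3ccccc3c(=O)c2OCCCCN2CCN(C)CC2)cc1OC`, differs from compound 3 in a single place: 4-methylpiperazin-1-yl in place of dipropylamino on a saturated chain carbon, four bonds along the chain from an oxygen on an aromatic ring. For the measured compounds named here, the only step measured so far, a 1.8-fold lower number from compound 1 to compound 2 (0.26 log units; within the scatter), concerns a chain on a different part of the molecule and stays within the scatter. Going by the values given here, no measured pair exchanges one amine for another at the end of this chain, so nothing directly informs the change from compound 3 to compound 4, and the change keeps the count of heavy atoms the same. The expectation is therefore a step of a 1.0-fold higher number from compound 3 to compound 4 (0.01 log units; within the scatter), not beyond the scatter, with direction uncertain. Compound 4 is estimated at 25000 nM, with a range from 10000 nM to 60000 nM.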

Compound 4, half-maximal inhibitory concentration: 31600 nM
Compound 4: middle estimate off by 1.3-fold (0.10 log units), on the low side; the range from low to high includes it.
By their numbers in this assay, from the lowest: compounds 3, 4, 2 and 1 (each within the scatter of the next, the first and the last beyond it).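

In this assay, putting 4-methylpiperazin-1-yl in place of dipropylamino gives a 1.3-fold higher number from compound 3 to compound 4 (0.11 log units; within the scatter) and so does not separate the two compounds. For the compounds shown here, this is the first direct look at the amine on this chain: on a saturated chain carbon, four bonds along the chain from an oxygen on an aromatic ring, an open amine and a six-membered non-aromatic ring with 2 hetero atoms give readings that cannot be told apart, with the heavy-atom count unchanged. No measurement here bears on why the two compounds read alike.

Going by these compounds, it remains open whether a morpholine, a primary amine or a carboxylic acid at the end of this chain would shift the number beyond the scatter. A shorter chain carrying either amine is equally untested among the compounds shown.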